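Trimming an Aryl Group Ahead of a Cytotoxicity Read-out

The source may report more compounds than this note shows. Statements on the series, on what has been measured and on what is new or still open speak of the compounds shown alone.

Three measured compounds share one core. Compound 1 `O=C(O)c1cn(C2CC2)c2cc(N3CCN(C(=O)CN4CCN(Cc5ccccc5)CC4)CC3)c(F)cc2c1=O`, compound 2 `O=C(O)c1cn(C2CC2)c2cc(N3CCN(C(=O)CN4CCN(C(c5ccccc5)c5ccccc5)CC4)CC3)c(F)cc2c1=O` and compound 3 `CC(c1ccccc1)N1CCN(CC(=O)N2CCN(c3cc4c(cc3F)c(=O)c(C(=O)O)cn4C3CC3)CC2)CC1` were examined in an ADME assay on RAW264.7 cells (Mus musculus) for cytotoxicity, read by MTT assay, with a stated time of 72 h, tested at 50 uM; on this read-out higher numbers stand for more inhibition at the one concentration tested (going by the name of the read-out) and lower numbers for less inhibition; compound 1 gives 15.5%, compound 2 gives 25.9% and compound 3 gives 16.9%. Compound 2 and compound 3 differ by methyl in place of phenyl on a saturated chain carbon bound to an amine nitrogen in a ring and an aromatic carbon, a step of a number 9 percentage points lower from compound 2 to compound 3 (within the scatter). From compound 2 to compound 1 the change is hydrogen in place of phenyl on a saturated chain carbon bound to an amine nitrogen in a ring and an aromatic carbon, and the step is a number 10.4 percentage points lower from compound 2 to compound 1 (beyond the scatter). Compound 4 `CCN1CCN(CC(=O)N2CCN(c3cc4c(cc3F)c(=O)c(C(=O)O)cn4C3CC3)CC2)CC1` is not yet measured; it differs from compound 3 by hydrogen in place of phenyl on a saturated chain carbon bound to an amine nitrogen in a ring and a saturated chain carbon, the same kind of change, though the place is bound to a saturated chain carbon rather than an aromatic carbon. The expectation rests on the earlier step of a number 10.4 percentage points lower from compound 2 to compound 1 (beyond the scatter). Compound 4 is therefore expected at 8%, with a range from 0% to 18%, an estimated step of a number 8.9 percentage points lower from compound 3 to compound 4 (within the scatter) in this assay.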

Compound 4, a percentage reported as inhibition, at one concentration (the size of the read-out at that concentration, not a potency): 13.3%
Beside the measured number, compound 4's estimate is 5.3 percentage points below it; the measured number falls inside the stated range.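

In this assay, hydrogen in place of phenyl gives a number 3.6 percentage points lower from compound 3 to compound 4 (within the scatter), which agrees with the same change on the other core: the same change on two cores in this assay, a number 10.4 percentage points lower (beyond the scatter) from compound 2 to compound 1 and a number 3.6 percentage points lower (within the scatter) from compound 3 to compound 4, 6.8 percentage points apart, within the scatter of two such steps. Methyl in place of phenyl gives a number 2.2 percentage points lower from compound 1 to compound 4 (within the scatter), and this also agrees with its earlier counterpart: the same change on two cores in this assay, a number 9 percentage points lower (within the scatter) from compound 2 to compound 3 and a number 2.2 percentage points lower (within the scatter) from compound 1 to compound 4, 6.8 percentage points apart, within the scatter of two such steps. Within the data shown here, each change keeps its direction from one core to the other, yet both new steps lie within the scatter, so alone they do not show a real drop, and only the step from compound 2 to compound 1 stands beyond it.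

The compounds shown leave open whether the pattern holds when a cyclohexyl group or a pyridine ring takes the place of phenyl. They also leave open whether it survives replacing the carboxylic acid of the shared core with an amide.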